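A few compounds are considered here, and "the series" means these few. Any claim that something is new, unique, unknown or untested is made for them only; others in the source may bear on it.

Among the measured compounds shown here, compound 2 `C/C(=N\Nc1nc2ccccc2nc1Cc1ccccc1)c1ccccc1` gives the lowest of the three numbers so far in an assay on isolated protein for inhibition of Amine oxidase [flavin-containing] A (Homo sapiens), read by spectrophotometry (on this read-out lower numbers stand for stronger inhibition and higher numbers for weaker inhibition), with 79 nM. Compound 1 `COc1ccc(/C(C)=N/Nc2nc3ccccc3nc2Cc2ccccc2)cc1` stands very close to it, at 89 nM, and the step of a 1.1-fold lower number from compound 1 to compound 2 (0.05 log units; within the scatter) is within the scatter. For the measured compounds named here, compound 3 `C/C(=N\Nc1nc2ccccc2nc1Cc1ccccc1)c1ccc([N+](=O)[O-])cc1` gives 680 nM, and the step of an 8.6-fold higher number from compound 2 to compound 3 (0.93 log units; beyond the scatter) is the only change beyond the scatter among the three. Compound 4 `Brc1cccc(/C=N/Nc2nc3ccccc3nc2Cc2ccccc2)c1` differs from compound 2 by a group of 9 heavy atoms (7 carbon, 1 nitrogen, 1 bromine; one six-membered aromatic ring of carbon only) in place of a group of 9 heavy atoms (8 carbon, 1 nitrogen; one six-membered aromatic ring of carbon only), on a nitrogen on an aromatic ring: the methyl on the double bond is gone and a bromine sits on the ring. Going by the values given here, no measured step matches this change directly; the nearest ones, a 1.1-fold lower number from compound 1 to compound 2 (0.05 log units; within the scatter) and an 8.6-fold higher number from compound 2 to compound 3 (0.93 log units; beyond the scatter), show that a change on that ring can leave the number unchanged or raise it modestly. A step of a 2.0-fold higher number from compound 2 to compound 4 (0.31 log units; beyond the scatter) is therefore expected, somewhat higher but not far from compound 2. For compound 4 the estimate in this assay is 160 nM, with a range from 50 nM to 500 nM.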

Compound 4, half-maximal inhibitory concentration: 9.8 nM
Compound 4: the middle estimate sits 16-fold (1.21 log units) above what was measured; measured number outside the range, below it.
By their numbers in this assay, from the lowest: compound 4; then compounds 2 and 1 (each within the scatter of the next); then compound 3.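

In this assay, the swap at this place gives an 8.1-fold lower number from compound 2 to compound 4 (0.91 log units; beyond the scatter), the first step among these compounds to lower the number beyond the scatter; the earlier changes on the ring left it unchanged or raised it. So the group on the nitrogen on an aromatic ring can be altered with a clear gain in inhibition, but this swap removes the methyl on the double bond and adds a bromine on the ring in a single step. Nothing shown explains why the number falls.

The compounds shown leave open how much of the step belongs to the loss of the methyl and how much to the bromine. They also leave open whether a chlorine, an amine or a carboxylic acid on the ring would lower the number in the same way.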